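Swapping the acyl chain of a trimethoxyphenyl amide

The source may hold more compounds than are shown below. What is called first, only, known or untested is meant among the compounds shown, and "the series" means these compounds.

In a functional assay on KYSE-450 cells (Homo sapiens) for inhibition, read by MTT assay, with a stated time of 48 h (a lower number here means a stronger inhibitor, a higher number a weaker inhibitor), compound 3 `COc1ccc(CN(C(=O)C(C)C)c2cc(OC)c(OC)c(OC)c2)cc1O` gives 390 nM. Compound 2 `COc1ccc(CN(C(=O)CO)c2cc(OC)c(OC)c(OC)c2)cc1O` gives 370 nM and compound 1 `CCCCC(=O)N(Cc1ccc(OC)c(O)c1)c1cc(OC)c(OC)c(OC)c1` gives 300 nM, so compound 3 stands alongside both: a 1.1-fold higher number from compound 2 to compound 3 (0.02 log units; within the scatter) and a 1.3-fold higher number from compound 1 to compound 3 (0.11 log units; within the scatter). Compound 4 `C=CC(=O)N(Cc1ccc(OC)c(O)c1)c1cc(OC)c(OC)c(OC)c1` differs from compound 3 by vinyl in place of isopropyl on a carbonyl carbon. Among the measured compounds shown here, the steps that bear on this place are the three acyl swaps already measured, a 1.2-fold higher number from compound 1 to compound 2 (0.09 log units; within the scatter), a 1.3-fold higher number from compound 1 to compound 3 (0.11 log units; within the scatter) and a 1.1-fold higher number from compound 2 to compound 3 (0.02 log units; within the scatter), and none of them moved the number beyond the scatter. Because a 1.1-fold higher number from compound 2 to compound 3 (0.02 log units; within the scatter) and a 1.3-fold higher number from compound 1 to compound 3 (0.11 log units; within the scatter) stayed flat, the expected step of a 1.1-fold lower number from compound 3 to compound 4 (0.05 log units; within the scatter) is again small, with no clear direction. Compound 4 is therefore estimated at 350 nM, with a range of 150 nM to 800 nM in this assay.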

Compound 4, half-maximal inhibitory concentration: 160 nM
Estimate against measurement, compound 4: 2.2-fold (0.34 log units) above, and the stated range covers the measured number.
By their numbers in this assay, from the lowest: compounds 4, 1, 2 and 3 (each within the scatter of the next, the first and the last beyond it).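

Among the compounds shown here, on this carbonyl carbon, vinyl gives the first steps beyond the scatter, both against isopropyl (a 2.4-fold lower number from compound 3 to compound 4 (0.39 log units; beyond the scatter)) and against hydroxymethyl (a 2.3-fold lower number from compound 2 to compound 4 (0.36 log units; beyond the scatter)). Against butyl the change stays within the scatter (a 1.9-fold lower number from compound 1 to compound 4 (0.27 log units; within the scatter)), so vinyl does not stand clear of all three other groups. No evidence shown here accounts for these steps.

From the compounds shown here alone, whether the double bond matters remains open, since an ethyl group on the same carbonyl carbon would be the direct comparison. Going by these compounds, how an amine at this place would behave is also open.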